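This account rests on a few compounds, and the source may have more. Where it says the series, first, only, none or still open, it means among the compounds named here.

Measured so far in an ADME assay on the whole organism (Rattus norvegicus) for pharmacokinetics, at a dose of 2 mg/kg by the intravenous route; a lower number here means slower removal, a higher number faster removal of the compound:

Compound 1 (`CCc1cccc(CC)c1N1CCn2cc(-c3nc(Nc4ccc(N5CCC(C(=O)N6CCN(C)CC6)CC5)cc4OC)nc4[nH]ccc34)cc2C1=O`): 1.7 mL/min/kg
Compound 2 (`CCc1cccc(CC)c1N1CCn2cc(-c3nc(Nc4ccc(N5CCC(C(=O)N(C)CCN(C)C)CC5)cc4OC)nc4[nH]ccc34)cc2C1=O`): 27 mL/min/kg

Compound 2 stands at the higher of these two numbers, well clear of compound 1. Compound 3 (`CCc1cccc(CC)c1N1CCn2cc(-c3nc(Nc4ccc(N5CCC(C(=O)N6CC7(CN(C)C7)C6)CC5)cc4OC)nc4[nH]ccc34)cc2C1=O`) departs from compound 2 through one change: a group of 8 heavy atoms (6 carbon, 2 nitrogen; 2 four-membered non-aromatic rings with 1 hetero atom each) in place of a group of 7 heavy atoms (5 carbon, 2 nitrogen; no ring), on a carbonyl carbon and nothing else. Among the compounds with values here, the one measured step bearing on this is a 16-fold higher number from compound 1 to compound 2 (1.20 log units; beyond the scatter) and it is large. That step put the open (2-(dimethylamino)ethyl)(methyl)amino group in place of 4-methylpiperazin-1-yl. Within the data shown here, compound 3 removes that open group again, though the group that enters is not the one in compound 1. With a single step as evidence, a sizeable move back towards compound 1 is expected, to a lower number in this assay and probably not the whole way. The estimated step is a 3.4-fold lower number from compound 2 to compound 3 (0.53 log units; beyond the scatter) and it is only an expectation. The estimate for compound 3 is 8 mL/min/kg with an expected range from 2.5 mL/min/kg to 22 mL/min/kg overall.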

Compound 3, clearance: 2.8 mL/min/kg
Estimate against measurement, compound 3: 2.9-fold (0.46 log units) above; the measured number falls inside the stated range.
By their numbers in this assay, from the lowest: compounds 1 and 3 (each within the scatter of the next); then compound 2.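

In this assay, putting the group with two four-membered non-aromatic rings in place of the open (2-(dimethylamino)ethyl)(methyl)amino group on the carbonyl carbon gives a 9.6-fold lower number from compound 2 to compound 3 (0.98 log units; beyond the scatter). Set against the 4-methylpiperazin-1-yl group, the same group gives a 1.6-fold higher number from compound 1 to compound 3 (0.22 log units; within the scatter), so compound 1 and compound 3 cannot be told apart in this measurement. The high number of compound 2 is therefore not tied to one particular ring: two different ring groups at this place both stand clear of the open chain.

Nothing shown explains this difference. Still open, from the compounds shown here alone, is whether the ring itself or the second nitrogen matters here, which a morpholin-4-yl group, or an open chain ending in a hydroxyl group, would help to separate.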